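Thiophen-2-yl replacing 3-(trifluoromethyl)phenyl in compound 2

The compounds below may be only part of what the source reports. "The series", "measured", "known", "first", "only" and "open" are said of these compounds alone.

Of the compounds shown here, three sharing one core have been measured in a functional assay on Hs 683 cells (Homo sapiens) for cytotoxicity, read by MTT assay (a lower number here means a stronger inhibitor, a higher number a weaker inhibitor), so far. Compound 1 `Oc1ccc(CN(Cc2ccccc2)Cc2ccc(O)c3ncccc23)c2cccnc12` gives 76 nM in this test, compound 2 `Oc1ccc(CN(Cc2cccc(C(F)(F)F)c2)Cc2ccc(O)c3ncccc23)c2cccnc12` gives 36 nM as the lowest number of the three, and compound 3 `Oc1ccc(CN(Cc2cc(C(F)(F)F)cc(C(F)(F)F)c2)Cc2ccc(O)c3ncccc23)c2cccnc12` gives 181 nM as the highest.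

Compound 4 `Oc1ccc(CN(Cc2cccs2)Cc2ccc(O)c3ncccc23)c2cccnc12` has not yet been measured. It differs from compound 2 by thiophen-2-yl in place of 3-(trifluoromethyl)phenyl on a saturated chain carbon bound to an amine nitrogen.

Within the data shown here, two measured steps bear on this change, and both put trifluoromethyl in place of hydrogen on an aromatic carbon. The number falls in one (a 2.1-fold lower number from compound 1 to compound 2 (0.32 log units; beyond the scatter)) and rises in the other (a 5.0-fold higher number from compound 2 to compound 3 (0.70 log units; beyond the scatter)), so they set no single trend. Among the measured compounds shown here, neither step replaces the ring itself, and no thiophen-2-yl compound has a value yet. Compound 4 carries no trifluoromethyl, so compound 1 at 76 nM is taken as the nearest guide.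

A modest step toward a higher number is therefore expected, and the estimated move is a 2.2-fold higher number from compound 2 to compound 4 (0.35 log units; beyond the scatter) in this assay as the working figure. The expected value for compound 4 is 80 nM with an estimated range of 30 nM to 220 nM in this test.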

Compound 4, half-maximal inhibitory concentration: 35 nM
Compound 4: middle estimate off by 2.3-fold (0.36 log units), on the high side, within the range that was stated.
By their numbers in this assay, from the lowest: compounds 4 and 2 (each within the scatter of the next); then compound 1; then compound 3.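

In this assay, the place on a saturated chain carbon bound to an amine nitrogen accepts a five-membered aromatic ring with 1 hetero atom: thiophen-2-yl, with 5 heavy atoms, stands level with 3-(trifluoromethyl)phenyl, with 10 heavy atoms, as a 1.0-fold lower number from compound 2 to compound 4 (0.01 log units; within the scatter) shows. Among these compounds, measured against the plain phenyl group, the same ring gives a 2.2-fold lower number from compound 1 to compound 4 (0.34 log units; beyond the scatter) and so matches compound 2 with no trifluoromethyl present, something the earlier compounds, where every number at this place was tied to phenyl with or without trifluoromethyl, could not show. Nothing available here accounts for how these rings compare.

As far as these compounds go, it remains open whether this result is particular to thiophen-2-yl or extends to other rings at this place, such as thiophen-3-yl, furan-2-yl, a pyridine ring or saturated cyclohexyl. Equally open, from the compounds shown here alone, is whether a chloro or methyl group on the thiophene ring would move the number up, as the second trifluoromethyl did in compound 3, or down, as the first did in compound 2.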